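The compounds below may be only part of what the source reports. "The series", "measured", "known", "first", "only" and "open" are said of these compounds alone.

Series notes. Three members of the series have been run in an ADME assay on HepG2 2.2.15 cells (Homo sapiens) for cytotoxicity; on this read-out lower numbers stand for higher toxicity in this test and higher numbers for lower toxicity in this test: compound 1 `Clc1ccc(C(Oc2ccc3cc(Br)ccc3c2)c2cnc(NCC3CCCCC3)s2)cc1`, compound 2 `O=C(Nc1ncc(C(Oc2ccc3cc(Br)ccc3c2)c2ccc(Cl)cc2)s1)C1CC1` and compound 3 `CCCCCC(=O)Nc1ncc(C(Oc2ccc3cc(Br)ccc3c2)c2ccc(Cl)cc2)s1`. In this assay compound 1 gives "not toxic" (no number reported). In this assay compound 2 gives "not toxic" (no number reported). For compound 3 this assay reports only a limit, > 50000 nM, and no number. Going by the values given here, compound 3 thus stands at the limit of > 50000 nM in this assay, at which 1 of the 3 values shown sits, while the other two entries of the set come without a single number, so no step between measured compounds can be read off here.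

Compound 4 `COc1ccc(C(=O)Nc2ncc(C(Oc3ccc4cc(Br)ccc4c3)c3ccc(Cl)cc3)s2)cc1` has not yet been measured. It differs from compound 3 by 4-methoxyphenyl in place of pentyl on a carbonyl carbon. With every value of the set pointing to low cytotoxicity, no shift beyond the scatter is expected in this assay, the expected step being a step that the limit leaves unreadable from compound 3 to compound 4. The estimate for compound 4 in this assay is 60000 nM, ranging from 25000 nM to 150000 nM, and most likely it will again be returned only as a limit.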

Compound 4, half-maximal cytotoxic concentration: > 50000 nM
Compound 4: no number, only a limit; the forecaster's own chance of this, stated with the estimate: 75%; the middle value lies beyond the limit too.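

Going by these compounds alone, compound 3 and compound 4 both return only limits in this assay and no number, so no step between them can be read. The compounds shown leave open whether 4-methoxyphenyl in place of pentyl on a carbonyl carbon shifts the read-out at all, and at what concentration any cytotoxicity would appear.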